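Swapping the dimethylamino of compound 1 for a methylpyrrolidine

The source may hold more compounds than are shown below. What is called first, only, known or untested is meant among the compounds shown, and "the series" means these compounds.

Within the data shown here, compound 1 `CN(C)c1c(C#N)c2c(N)ncnc2n1C` is one of three compounds measured in an assay on isolated protein for inhibition of Leucine-rich repeat serine/threonine-protein kinase 2 (Homo sapiens), read by TR-FRET and LanthaScreen, with stated times of 50 min and 30 min, in the presence of a further agent that is not named here (a lower number here means a stronger inhibitor, a higher number a weaker inhibitor), where compound 1 gives 4620 nM. Compound 3 `C[C@@H]1CCCN1c1cc2c(N)ncnc2n1C` gives 6830 nM, within the scatter of compound 1. Compound 2 `C[C@@H]1CCCN1c1c(C#N)c2c(N)nc(Nc3cn[nH]c3)nc2n1C` gives 6 nM, far beyond the scatter from both. Compound 4 `C[C@H]1CCCN1c1c(C#N)c2c(N)ncnc2n1C` differs from compound 1 in one place: 2-methylpyrrolidin-1-yl in place of dimethylamino on an aromatic carbon. Among the measured compounds shown here, no step between measured compounds isolates this change, and compound 2 differs from compound 4 in a further place. Because compound 3 gives 6830 nM with the same 2-methylpyrrolidin-1-yl present, compound 4 is expected near compound 1, with the step of a 1.2-fold lower number from compound 1 to compound 4 (0.06 log units; within the scatter) estimated as none beyond the scatter. Compound 4 is thus estimated at 4000 nM, with a range from 1200 nM to 13000 nM.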

Compound 4, half-maximal inhibitory concentration: 5660 nM
Estimate against measurement, compound 4: 1.4-fold (0.15 log units) below; measured number inside the range.
By their numbers in this assay, from the lowest: compound 2; then compounds 1, 4 and 3 (each within the scatter of the next).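

In this assay, 2-methylpyrrolidin-1-yl in place of dimethylamino on this aromatic carbon gives a 1.2-fold higher number from compound 1 to compound 4 (0.09 log units; within the scatter). Among these compounds, this is the first direct reading of the change, and it shows that the ring and its defined stereocentre can replace dimethylamino here with no shift beyond the scatter. Nothing available explains why the number holds. As far as these compounds go, it remains open whether a morpholine, a piperidine or an unsubstituted pyrrolidine at this position would move the number. From the compounds shown here alone, the opposite configuration at the stereocentre on this same core also remains open.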